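The source may hold more compounds than are shown below. What is called first, only, known or untested is meant among the compounds shown, and "the series" means these compounds.

Measured in a functional assay on HCT-116 cells (Homo sapiens) for cytotoxicity, read by MTT assay, with a stated time of 48 h; on this read-out higher numbers stand for weaker inhibition of growth and lower numbers for stronger inhibition of growth:
- compound 1 `C=CCn1c(C(F)(F)F)nc2cc(Cl)c(Cl)cc21`: 89200 nM
- compound 2 `Nc1ccccc1Cn1c(C(F)(F)F)nc2cc(Cl)c(Cl)cc21`: 26100 nM

Of these two, compound 2 gives the lower number, 26100 nM, which means stronger inhibition of growth. Compound 3 `Nc1cccc(Cn2c(C(F)(F)F)nc3cc(Cl)c(Cl)cc32)c1`, not yet measured, has the same atoms as compound 2, joined differently: 3-aminophenyl in place of 2-aminophenyl on a saturated chain carbon bound to an aromatic nitrogen. In words, 3-aminophenyl takes the place of 2-aminophenyl on a saturated chain carbon bound to an aromatic nitrogen.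

Going by the values given here, only one measured step bears on this, and only loosely: a 3.4-fold lower number from compound 1 to compound 2 (0.53 log units; beyond the scatter). That modest step exchanged vinyl for 2-aminophenyl, so it says nothing direct about swapping 2-aminophenyl for 3-aminophenyl. With so little evidence, no clear direction can be argued, and a change no larger than that modest step is expected. The expected step is a 1.1-fold higher number from compound 2 to compound 3 (0.06 log units; within the scatter), probably within the scatter. For compound 3 the estimated value is 30000 nM, with an expected range from 12000 nM to 75000 nM.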

Compound 3, concentration for 50% growth inhibition: 22600 nM
Estimate against measurement, compound 3: 1.3-fold (0.12 log units) above; the range from low to high includes it.
By their numbers in this assay, from the lowest: compounds 3 and 2 (each within the scatter of the next); then compound 1.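

Putting 3-aminophenyl in place of 2-aminophenyl on the saturated chain carbon bound to an aromatic nitrogen gives a 1.2-fold lower number from compound 2 to compound 3 (0.06 log units; within the scatter) in this assay, so this read-out does not tell these two aminophenyl groups apart at this place. The modest advantage over the vinyl group of compound 1 is therefore not limited to 2-aminophenyl, as 3-aminophenyl also gives a 3.9-fold lower number from compound 1 to compound 3 (0.60 log units; beyond the scatter) in this assay, a step beyond the scatter. No independent measurement is available to explain either step.

The compounds shown leave open whether the amine on the ring matters at all, or whether the ring alone accounts for the step away from vinyl. A plain phenyl ring, or a carboxylic acid in place of the amine, would help to separate the two.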